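This account rests on a few compounds, and the source may have more. Where it says the series, first, only, none or still open, it means among the compounds named here.

Of the compounds shown here, three built on one shared core have been tested in a functional assay on MCF7 cells (Homo sapiens) for cytotoxicity, read by MTT assay, with a stated time of 48 h; a lower number here means a stronger inhibitor, a higher number a weaker inhibitor. Compound 1 `COc1cc(-c2nnc3n2NC(c2ccco2)C(C(=O)c2ccccc2C)S3)cc(OC)c1OC`, which carries 2-methylphenyl on a carbonyl carbon, gives 69900 nM. Compound 2 `COc1cc(C(=O)C2Sc3nnc(-c4cc(OC)c(OC)c(OC)c4)n3NC2c2ccco2)cc(OC)c1OC` carries 3,4,5-trimethoxyphenyl on a carbonyl carbon, and in this assay compound 2 reaches only the limit of the assay, > 100000 nM. Compound 3 `COc1cc(-c2nnc3n2NC(c2ccco2)C(C(=O)c2ccc(Br)cc2)S3)cc(OC)c1OC` carries 4-bromophenyl, and in this assay compound 3 likewise stops at the limit > 100000 nM. Compound 2 thus stands at the limit of > 100000 nM in this assay, at which 2 of the 3 values shown sit. Compound 4 `COc1cc(-c2nnc3n2NC(c2ccco2)C(C(=O)c2ccc(C)cc2)S3)cc(OC)c1OC` is not yet measured; it differs from compound 2 by 4-methylphenyl in place of 3,4,5-trimethoxyphenyl on a carbonyl carbon. The steps of an at least 1.4-fold higher number from compound 1 to compound 2 (0.15 log units; that floor lies within the scatter) and an at least 1.4-fold higher number from compound 1 to compound 3 (0.15 log units; that floor lies within the scatter) set only floors, and a step that the two limits leave unreadable from compound 2 to compound 3. Compound 1, with its methylphenyl, gives 69900 nM. On that basis compound 4 is expected to land near it, an estimated step of an at least 1.2-fold lower number from compound 2 to compound 4 (0.09 log units; that floor lies within the scatter). The estimate for compound 4 is 80000 nM, ranging from 30000 nM to 200000 nM.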

Compound 4, half-maximal inhibitory concentration: > 100000 nM
Compound 4 gave a limit, no number; the forecaster's own chance of this, stated with the estimate: 50%; middle value at least 1.2-fold (0.09 log units) away from the limit.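

Putting 4-methylphenyl in place of 2-methylphenyl on the carbonyl carbon gives an at least 1.4-fold higher number from compound 1 to compound 4 (0.15 log units; that floor lies within the scatter), so the two methylphenyl compounds cannot yet be told apart. The steps from compound 4 to compound 2 and compound 3 cannot be read, since both ends of each are limits, and having a methylphenyl group here does not by itself ensure a measurable value. Most of the series now shares a single limit: the limit of > 100000 nM in this assay, at which 3 of the 4 values shown sit.

The compounds shown leave open whether an amine or a carboxylic acid on this phenyl ring would give a value clearly inside the range of the assay.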